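Chloro to methoxy on the benzyl ether of compound 1

The source may hold more compounds than are shown below. What is called first, only, known or untested is meant among the compounds shown, and "the series" means these compounds.

Compound 1 `COc1cccc(OC)c1OCCNCCOc1ccccc1OCc1ccc(Cl)cc1` carries a 4-chlorophenyl group on a saturated chain carbon bound to an oxygen on an aromatic ring. In a functional assay on PC-3 cells (Homo sapiens) for cytotoxicity, read by sulforhodamine B assay (a higher number here means a weaker inhibitor of growth, a lower number a stronger inhibitor of growth), compound 1 gives 2400 nM, the lowest number among the three measured compounds. Compound 3 `COc1cccc(COc2ccccc2OCCNCCOc2c(OC)cccc2OC)c1` gives 2500 nM, and the step of a 1.0-fold higher number from compound 1 to compound 3 (0.02 log units; within the scatter) stays within the scatter. Compound 2 `COc1ccccc1COc1ccccc1OCCNCCOc1c(OC)cccc1OC` gives 8900 nM; the step of a 3.7-fold higher number from compound 1 to compound 2 (0.57 log units; beyond the scatter) is the one clear shift in the set, and a 3.6-fold lower number from compound 2 to compound 3 (0.55 log units; beyond the scatter) shows the same gap from the other side. Compound 4 `COc1ccc(COc2ccccc2OCCNCCOc2c(OC)cccc2OC)cc1` is not yet measured; it differs from compound 1 by methoxy in place of chloro on an aromatic carbon. Among the compounds with values here, no measured step swaps chloro for methoxy on the same aromatic carbon, so the expectation rests on the two methoxy placements seen in compound 2 and compound 3: one left the number unchanged, the other raised it modestly. For compound 4 a small rise or no change beyond the scatter is therefore expected, a 1.3-fold higher number from compound 1 to compound 4 (0.12 log units; within the scatter). Compound 4 is estimated at 3200 nM, with a range from 1500 nM to 7500 nM.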

Compound 4, concentration for 50% growth inhibition: 8500 nM
The estimate for compound 4 lay 2.7-fold (0.42 log units) below the measured number, outside the stated range (above it).
By their numbers in this assay, from the lowest: compounds 1 and 3 (each within the scatter of the next); then compounds 4 and 2 (each within the scatter of the next).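

The direct swap of chloro for methoxy on this aromatic carbon, para to a large group, now has its own reading in this assay (a 3.5-fold higher number from compound 1 to compound 4 (0.55 log units; beyond the scatter)), so the two groups do not behave alike here. Where the methoxy sits also counts: moving it gives a 3.4-fold higher number from compound 3 to compound 4 (0.53 log units; beyond the scatter) and then, on the other side, a 1.0-fold lower number from compound 2 to compound 4 (0.02 log units; within the scatter) with no real change. Of the three methoxy placements, only the 3-methoxyphenyl of compound 3 stays level with the 4-chlorophenyl of compound 1, while compound 2 and compound 4 share the higher number.

As far as these compounds go, whether a fluoro or a trifluoromethyl group on this same carbon would track chloro or methoxy remains open. The compounds come with no measurement that explains these steps.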